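Nitro to bromo on the aryl of compound 2

The compounds below may be only part of what the source reports. "The series", "measured", "known", "first", "only" and "open" are said of these compounds alone.

Measured so far in this series:
compound 1, `COc1ccc(C2CC(c3ccc(OCc4cn(Cc5ccc([N+](=O)[O-])cc5)nn4)cc3)=NN2C(C)=O)cc1`, in a functional assay on THP-1 cells (Homo sapiens) for inhibition, read by sulforhodamine B assay, tested at 10 uM (on this read-out lower numbers stand for less inhibition of growth and higher numbers for more inhibition of growth at the one concentration tested), compound 1 gives 15%
compound 2, `COc1cc(C2CC(c3ccc([N+](=O)[O-])cc3)=NN2C(C)=O)ccc1OCc1cn(Cc2ccc([N+](=O)[O-])cc2)nn1`, in this assay compound 2 gives 7%

Compound 2 stands at the lower of the two numbers, but compound 1 lies within the scatter of it, so the two are not told apart; both read as weak inhibition of growth at the one concentration tested.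

Compound 3, `COc1cc(C2CC(c3ccc(Br)cc3)=NN2C(C)=O)ccc1OCc1cn(Cc2ccc([N+](=O)[O-])cc2)nn1`, differs from compound 2 by bromo in place of nitro on an aromatic carbon. For the measured compounds named here, no measured pair in the set carries this change, so there is no step to draw on. With both measured compounds sitting low on the read-out, the change is expected to leave the number within the scatter: the step of a number 3 percentage points higher from compound 2 to compound 3 (within the scatter) is expected to be none beyond the scatter. Compound 3 is thus estimated at 10%, with a range from 0% to 25%.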

Compound 3, percent growth inhibition at one concentration: 1%
Beside the measured number, compound 3's estimate is 9 percentage points above it; the measured number falls inside the stated range.
By their numbers in this assay, from the lowest: compounds 3, 2 and 1 (each within the scatter of the next, the first and the last beyond it).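

In this assay the change from 4-nitrophenyl to 4-bromophenyl reads as a number 6 percentage points lower from compound 2 to compound 3 (within the scatter) and gives the series its first comparison in one place. On this aromatic carbon, para to a large group, bromo can stand in for nitro without separating the two compounds, even with 1 heavy atom in place of 3 and no hydrogen-bond acceptors in place of 2, so the nitro group at this position is not shown to matter for the read-out. No measurement at hand explains the result.

On these data alone, whether an amine or a carboxylic acid at this position would move the number beyond the scatter stays open. Also open, as far as these compounds go, is what replacing the nitro group that compound 2 and compound 3 share would do.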